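Fluoro Added to a Fluorobenzyl Imidazole Series

The source may report more compounds than this note shows. Statements on the series, on what has been measured and on what is new or still open speak of the compounds shown alone.

Compound 1 `COc1ccc(NCc2cncn2Cc2ccc(-c3ccccc3)cc2N)cc1-c1ccccc1` and compound 2 `COC(=O)c1ccc(NCc2cncn2Cc2cccc(F)c2)cc1-c1ccccc1` were both tested in a toxicity assay on NIH3T3 cells (Mus musculus) for cytotoxicity, read by resazurin assay; a lower number here means that less compound is needed, a higher number that more compound is needed for the effect. In this assay compound 1 gives > 1000 nM, which is a limit of the assay and not a number. Compound 2 likewise gives in this assay only a limit, > 1000 nM. Both of these values sit at the limit of > 1000 nM in this assay, at which 2 of the 3 values shown sit. Compound 3 `COC(=O)c1ccc(NCc2cncn2Cc2ccccc2F)cc1-c1ccccc1` shares its core with compound 2 and carries a 2-fluorobenzyl group; in this assay compound 3 is recorded as "not determined" (no result reported), so no number is known for it and it cannot be placed against compound 1 or compound 2. Compound 4 `COC(=O)c1ccc(NCc2cncn2Cc2ccc(F)cc2F)cc1-c1ccccc1` has not yet been measured. It differs from compound 3 by fluoro in place of hydrogen on an aromatic carbon. For the measured compounds named here, no step between two measured compounds exists in this set, so the size of the change from compound 3 to compound 4 in this assay cannot be read from any neighbouring pair; the expectation is that it stays within the scatter, because the values of compound 1 and compound 2 sit at the limit of > 1000 nM in this assay, at which 2 of the 3 values shown sit, and nothing points the other way. Compound 4 is therefore expected to give in this assay about 2500 nM, with a range from 800 nM to 10000 nM, and most likely to be reported as a limit rather than a number.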

Compound 4, half-maximal effective concentration: > 1000 nM
Compound 4: a limit, no number; the forecaster's own chance of this, stated with the estimate: 80%; the middle value lies beyond the limit too.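

In this assay compound 4 gives > 1000 nM, which is a limit of the assay and not a number. For the compounds shown here, compound 2 also carries only a limit, and no step from compound 2 to compound 4 can be read from the two. The compounds shown leave open how much of compound 1, compound 2 or compound 4 is needed for the effect, and whether the 2,4-difluorobenzyl group makes any difference to it.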